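Thiophen-3-yl gives way to ethynyl on a shared core

The source may report more compounds than this note shows. Statements on the series, on what has been measured and on what is new or still open speak of the compounds shown alone.

In a functional assay on HepG2 cells (Homo sapiens) for antiproliferative activity, read by XTT assay, with a stated time of 72 h (a lower number here means a stronger inhibitor, a higher number a weaker inhibitor), compound 1 `C#Cc1cn([C@@H]2O[C@H](CO)[C@@H](O)[C@H]2O)c2ncnc(N(C)C)c12` gives 1320 nM. Compound 2 `Cc1ncnc2c1c(-c1ccsc1)cn2[C@@H]1O[C@H](CO)[C@@H](O)[C@H]1O` gives 4720 nM, the higher of the two numbers, which makes it the weaker inhibitor of the pair by a gap beyond the usual scatter. These two compounds differ in more than one place, so their gap cannot be tied to a single change.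

Compound 3 `C#Cc1cn([C@@H]2O[C@H](CO)[C@@H](O)[C@H]2O)c2ncnc(C)c12` departs from compound 2 in one place only: ethynyl in place of thiophen-3-yl on an aromatic carbon. Ethynyl stands in place of thiophen-3-yl on an aromatic carbon of a five-membered aromatic ring with 1 nitrogen. Within the data shown here, no measured pair isolates this exchange, so any forecast is tentative. Among the measured compounds shown here, the only guide is compound 1, which also carries ethynyl and reads 1320 nM. On that basis, a moderate move towards a lower number is expected in this assay, probably beyond the scatter. The estimated size of this move is a 3.9-fold lower number from compound 2 to compound 3 (0.59 log units; beyond the scatter). For compound 3 the expected value is 1200 nM, with an estimated range from 250 nM to 5000 nM.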

Compound 3, half-maximal inhibitory concentration: 290 nM
Compound 3: middle estimate off by 4.1-fold (0.62 log units), on the high side; measured number inside the range.
By their numbers in this assay, from the lowest: compound 3; then compound 1; then compound 2.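

With methyl held on the shared core, the exchange of thiophen-3-yl for ethynyl on an aromatic carbon of the five-membered aromatic ring with 1 nitrogen now stands alone, and in this assay it brings a 16-fold lower number from compound 2 to compound 3 (1.21 log units; beyond the scatter) as a large step, so at this position the ring-free group of 2 heavy atoms reads far better than the ring of 5. With ethynyl held, methyl in place of dimethylamino on an aromatic carbon brings a 4.6-fold lower number from compound 1 to compound 3 (0.66 log units; beyond the scatter) as a modest step, which shows that ethynyl does not set the number alone and that the second position also moves it. Nothing measured on these compounds gives a reason for either step.

Among these compounds, only two groups are compared at each of these positions, so it remains open whether a nitrile, a propynyl chain or an ethyl group could match ethynyl on the first carbon, and whether chlorine or a primary amine could match methyl on the second. Going by these compounds, whether these two exchanges would add up in the same way on other combinations of groups also remains open.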